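The compounds below may be only part of what the source reports. "The series", "measured", "known", "first", "only" and "open" are said of these compounds alone.

Measured compounds:

Compound 1 `Brc1cccc(Cc2nnc(Cn3nnc4ccccc43)o2)c1` in an ADME assay on cells (Macrophage, Homo sapiens) for inhibition (a higher number here means that more compound is tolerated, a lower number that less compound is tolerated), gives > 100000 nM, which is a limit of the assay and not a number.
Compound 2 `Brc1ccc(Cc2nnc(Cn3nnc4ccccc43)o2)cc1` in this assay gives > 100000 nM, again a limit and not a number.
Compound 3 `Fc1cccc(Cc2nnc(Cn3nnc4ccccc43)o2)c1` in this assay gives > 100000 nM, likewise a limit and not a number.

Compound 2 therefore stands at a limit, and its two neighbours stand at the same one: the limit of > 100000 nM in this assay, at which 3 of the 3 values shown sit. The steps among them, a step that the two limits leave unreadable from compound 1 to compound 2, a step that the two limits leave unreadable from compound 1 to compound 3 and a step that the two limits leave unreadable from compound 2 to compound 3, are all left unreadable by those limits, so none of them shows whether a change on the pendant phenyl ring moves the read-out at all.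

Compound 4 `O=[N+]([O-])c1ccc(Cc2nnc(Cn3nnc4ccccc43)o2)cc1` has not been measured. It differs from compound 2 in one place: nitro in place of bromo on an aromatic carbon. The three unreadable steps bear on this change only in that every alteration of the pendant ring so far has left the compound at the limit. Among the measured compounds shown here, no step of readable size exists, so no step beyond the scatter is expected in this assay in either direction. Compound 4 is estimated at 100000 nM, between 50000 nM and 200000 nM. The expected step is a number no higher from compound 2 to compound 4 (the limit leaves the size open), with the result most likely reported once more as a limit.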

Compound 4, half-maximal cytotoxic concentration: > 100000 nM
Compound 4 ended at the assay's limit (the forecaster's own chance of this, stated with the estimate: 85%); the middle value sits exactly at the limit.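

Compound 2 and compound 4 both stand at a limit and not at a number, so no new step can be read between them: the limit of > 100000 nM in this assay, at which 4 of the 4 values shown sit.

The compounds shown leave open whether any change on the pendant phenyl ring moves the half-maximal cytotoxic concentration at all.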